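Butoxy in place of methoxy on compound 2

The source may hold more compounds than are shown below. What is called first, only, known or untested is meant among the compounds shown, and "the series" means these compounds.

Values in a functional assay on MCF7 cells (Homo sapiens) for inhibition, read by sulforhodamine B assay, with a stated time of 48 h, tested at 50 uM (on this read-out lower numbers stand for less inhibition of growth and higher numbers for more inhibition of growth at the one concentration tested), for the measured compounds
compound 1 `COc1cc2c(cc1CCC(C)C)C(=O)C[C@@H](c1ccc(O)cc1)O2` gives 81%
compound 2 `COc1ccc([C@@H]2CC(=O)c3cc(CC=C(C)C)c(OC)cc3O2)cc1` gives 65%
compound 3 `COc1ccc([C@@H]2C/C(=N/OCc3cn(-c4ccc(Cl)cc4C)nn3)c3cc(CC=C(C)C)c(OC)cc3O2)cc1` gives 37%

At 65% in this assay, compound 2 stands second highest of the three, with its gaps to the other two beyond the scatter. Compound 4 `CCCCOc1ccc([C@@H]2CC(=O)c3cc(CC=C(C)C)c(OC)cc3O2)cc1` differs from it by propyl in place of hydrogen on a saturated chain carbon bound to an oxygen on an aromatic ring, which also reads as methoxy to butoxy. For the measured compounds named here, no measured pair isolates this change. The only weak hint is that compound 3, the largest of the three, gives a lower 37% in this assay. A modest fall is therefore expected, possibly none beyond the scatter. The expected change is a number 9 percentage points lower from compound 2 to compound 4 (within the scatter) in this assay. Compound 4 is estimated at 56% (expected range 36% to 76%).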

Compound 4, percent growth inhibition at one concentration: 57%
Estimate against measurement, compound 4: 1 percentage points below; the measured number falls inside the stated range.
By their numbers in this assay, from the lowest: compound 3; then compounds 4 and 2 (each within the scatter of the next); then compound 1.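

In this assay, for the compounds shown here, the one matched pair at this position gives a number 8 percentage points lower from compound 2 to compound 4 (within the scatter). Methoxy to butoxy on a saturated chain carbon bound to an oxygen on an aromatic ring therefore brings no step beyond the scatter at the one concentration tested, so this position accepts the added propyl in this read-out. Nothing measured here gives a cause for this result.

On these data alone, whether a longer chain, or an amine or carboxylic acid at the end of the chain, would keep this level stays open. A single step also sets no trend with chain length.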